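Swapping the Pyridyl Amide for a Phenyl Sulfonamide

This account rests on a few compounds, and the source may have more. Where it says the series, first, only, none or still open, it means among the compounds named here.

Compound 3 `CN(C(=O)c1ccccn1)c1ccc(C(O)(C(F)(F)F)C(F)(F)F)cc1` is, in an ADME assay on Li23 cells (Homo sapiens) for cytotoxicity, read by WST assay (on this read-out lower numbers stand for higher toxicity in this test and higher numbers for lower toxicity in this test), one of two compounds whose value is only a limit of the assay: compound 3 gives > 100000 nM. Compound 2 `CCCC(=O)N(C)c1ccc(C(O)(C(F)(F)F)C(F)(F)F)cc1` likewise reaches only a limit, with > 100000 nM. Going by the values given here, compound 1 `Cc1cccc(C(=O)N(C)c2ccc(C(O)(C(F)(F)F)C(F)(F)F)cc2)c1` is the sole compound with a number, at 20000 nM. The steps of an at least 5.0-fold higher number from compound 1 to compound 2 (0.69 log units; beyond the scatter) and an at least 5.0-fold higher number from compound 1 to compound 3 (0.69 log units; beyond the scatter) both run upward, while a step that the two limits leave unreadable from compound 2 to compound 3 cannot be sized, as the limit of > 100000 nM in this assay, at which 2 of the 3 values shown sit, shows.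

Compound 4 `CN(c1ccc(C(O)(C(F)(F)F)C(F)(F)F)cc1)S(=O)(=O)c1ccccc1` differs from compound 3 by phenylsulfonyl in place of (pyridin-2-yl)carbonyl on a nitrogen on an aromatic ring. Among the compounds with values here, no measured step exchanges an amide carbonyl for a sulfonyl, so the steps in hand bear on it only loosely: compound 1 carries an aromatic ring on the carbonyl and sits at a readable number, whereas compound 3 with its pyridin-2-yl sits at the limit. With an aromatic ring returning on the sulfonyl, the estimate for compound 4 is a step downward, an at least 1.6-fold lower number from compound 3 to compound 4 (0.22 log units; that floor lies within the scatter), though it may again fall at the limit. The expected value for compound 4 is 60000 nM, between 15000 nM and 200000 nM.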

Compound 4, half-maximal cytotoxic concentration: 16000 nM
Compound 4: middle estimate off by 3.8-fold (0.57 log units), on the high side, and the stated range covers the measured number.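

In this assay the nitrogen on an aromatic ring can carry phenylsulfonyl and still give a readable number, with an at least 6.2-fold lower number from compound 3 to compound 4 (0.79 log units; beyond the scatter) and an at least 6.2-fold lower number from compound 2 to compound 4 (0.79 log units; beyond the scatter). These two steps can be read only as floors, because the starting values are not numbers: the limit of > 100000 nM in this assay, at which 2 of the 4 values shown sit. The step from the carbonyl group bearing 3-methylphenyl is small, a 1.3-fold lower number from compound 1 to compound 4 (0.10 log units; within the scatter), so the two compounds with an aromatic ring of carbon only on the linking group cannot be told apart here, while pyridin-2-yl and propyl on a carbonyl remain at the limit.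

From the compounds shown here alone, it remains open whether pyridin-2-yl or propyl on the sulfonyl would also reach the limit, which leaves the part played by the linking group separate from that of its substituent unresolved. Going by these compounds, how an amine or a carboxylic acid on the phenyl of the sulfonyl would read also remains open.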